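The compounds below may be only part of what the source reports. "The series", "measured", "known", "first", "only" and "open" are said of these compounds alone.

In a functional assay for inhibition, with Homo sapiens as the target (on this read-out higher numbers stand for weaker inhibition and lower numbers for stronger inhibition), compound 1 (`O=C(O)CCCCCCCn1nc(-c2ccccc2)c(-c2ccccc2)c1-c1ccccc1`) gives 3400 nM, and compound 2 (`O=C(O)CSCCCCCCn1nc(-c2ccccc2)c(-c2ccccc2)c1-c1ccccc1`) gives 870 nM, the lower of the two numbers. Compound 3 (`CS(=O)(=O)NC(=O)CCCCCCCCn1nc(-c2ccccc2)c(-c2ccccc2)c1-c1ccccc1`) follows with 2-((methylsulfonyl)carbamoyl)ethyl in place of (carboxymethyl)sulfanyl on a saturated chain carbon, six bonds along the chain from an aromatic nitrogen: 2-((methylsulfonyl)carbamoyl)ethyl in place of (carboxymethyl)sulfanyl, on a saturated chain carbon, six bonds along the chain from an aromatic nitrogen. Going by the values given here, the one measured step that bears on this is modest: a 3.9-fold lower number from compound 1 to compound 2 (0.59 log units; beyond the scatter), where (carboxymethyl)sulfanyl entered in place of carboxymethyl. Among the compounds with values here, compound 3 lacks that sulfanyl too, and no measured compound carries its new end group. A modest rise in this assay is therefore expected, with a 2.3-fold higher number from compound 2 to compound 3 (0.36 log units; beyond the scatter) as the estimated step. Compound 3 is estimated at 2000 nM, with an expected range of 500 nM to 7000 nM.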

Compound 3, half-maximal inhibitory concentration: 5900 nM
Beside the measured number, compound 3's estimate is 3.0-fold (0.47 log units) below it; measured number inside the range.
By their numbers in this assay, from the lowest: compound 2; then compounds 1 and 3 (each within the scatter of the next).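

In this assay, putting 2-((methylsulfonyl)carbamoyl)ethyl in place of (carboxymethyl)sulfanyl gives a 6.8-fold higher number from compound 2 to compound 3 (0.83 log units; beyond the scatter), so the advantage of compound 2 does not carry over to a chain without the sulfanyl. On the all-carbon chain, ((methylsulfonyl)carbamoyl)methyl in place of carboxy gives a 1.7-fold higher number from compound 1 to compound 3 (0.24 log units; within the scatter), which leaves compound 1 and compound 3 level in this read-out. No supporting data explain either step.

Still open, going by these compounds, is whether a chain keeping the sulfanyl and ending in (methylsulfonyl)carbamoyl would stay near compound 2. A primary amide end is also untested by these compounds.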